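Swapping Cyclopropyl for Methoxyphenyl on a Weaker Analogue

The source may hold more compounds than are shown below. What is called first, only, known or untested is meant among the compounds shown, and "the series" means these compounds.

Compound 1 `COc1ncc(-c2ccc3c(c2)N(C2CC2)C(=O)CO3)cc1NS(=O)(=O)c1ccc(F)cc1` and compound 3 `COc1ccc(N2C(=O)COc3ccc(-c4cnc(OC)c(NS(=O)(=O)c5ccc(F)cc5)c4)cc32)cc1` share one core and differ by 4-methoxyphenyl in place of cyclopropyl on an amide-type nitrogen in a ring. In a functional assay on HeLa cells (Homo sapiens) for antiproliferative activity, read by MTT assay, with a stated time of 72 h (a higher number here means a weaker inhibitor, a lower number a stronger inhibitor), compound 1 gives 6030 nM, while compound 3 gives 1220 nM, so that a 4.9-fold lower number from compound 1 to compound 3 (0.69 log units; beyond the scatter). Compound 2 `O=C1COc2ccc(-c3cccc(NS(=O)(=O)c4ccc(F)cc4)c3)cc2N1C1CC1` has another core; the difference between the two cores is not broken down here. In this assay compound 2 returns only a limit of the measurement, > 40000 nM. Compound 4 `COc1ccc(N2C(=O)COc3ccc(-c4cccc(NS(=O)(=O)c5ccc(F)cc5)c4)cc32)cc1` is not yet measured and differs from compound 2 by 4-methoxyphenyl in place of cyclopropyl on an amide-type nitrogen in a ring, the same change as between compound 1 and compound 3. The step from compound 2 to compound 4 is expected to be an at least 2.0-fold lower number from compound 2 to compound 4 (0.30 log units; that floor lies within the scatter), resting on a 4.9-fold lower number from compound 1 to compound 3 (0.69 log units; beyond the scatter). Because compound 2 sits at the limit of > 40000 nM in this assay, at which 1 of the 3 values shown sits, compound 4 may also give only a limit. Compound 4 is expected near 20000 nM, between 6000 nM and 80000 nM.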

Compound 4, half-maximal inhibitory concentration: 13200 nM
Beside the measured number, compound 4's estimate is 1.5-fold (0.18 log units) above it; low and high end bracket the measured number.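

Putting 4-methoxyphenyl in place of cyclopropyl on the amide-type nitrogen in a ring also pays off on the second core: in this assay there is an at least 3.0-fold lower number from compound 2 to compound 4 (0.48 log units; beyond the scatter). The number therefore falls on both cores, so the direction of the change carries over in these two pairs, though two cores cannot establish a rule for the wider series. Whether the size of the change also carries over is unsettled, as the two steps can only be set side by side: the same change on two cores in this assay, a 4.9-fold lower number (0.69 log units; beyond the scatter) from compound 1 to compound 3 and an at least 3.0-fold lower number (0.48 log units; beyond the scatter) from compound 2 to compound 4; the limit leaves it open whether they differ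

The compounds shown leave open how other groups on that nitrogen would behave, such as a longer chain like n-butyl or a phenyl ring bearing a carboxylic acid. They also leave open whether the same change would lower the number on any further core.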